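A few compounds are considered here, and "the series" means these few. Any claim that something is new, unique, unknown or untested is made for them only; others in the source may bear on it.

Compound 1 `FC(F)(F)c1ccc(/C=C\c2cc3ccc(Cl)cc3nc2Cl)cc1` and compound 2 `Fc1ccc(/C=C\c2cc3ccc(Cl)cc3nc2Cl)cc1` share one core, and compound 3 `COc1ccc2nc(Cl)c(/C=C\c3ccc(C(F)(F)F)cc3)cc2c1` carries a second core; the difference between the two cores is not broken down here. In a functional assay on MCF7 cells (Homo sapiens) for antiproliferative activity, read by sulforhodamine B assay, with a stated time of 72 h (on this read-out higher numbers stand for weaker inhibition and lower numbers for stronger inhibition), compound 1 gives 6450 nM, compound 2 gives 16900 nM, and compound 3 gives 12400 nM. The step from compound 1 to compound 2 is a single change fluoro in place of trifluoromethyl on an aromatic carbon and it moved the read-out as a 2.6-fold higher number from compound 1 to compound 2 (0.42 log units; beyond the scatter). Compound 4 `COc1ccc2nc(Cl)c(/C=C\c3ccc(F)cc3)cc2c1` is not yet measured; it differs from compound 3 by fluoro in place of trifluoromethyl on an aromatic carbon and the two places agree word for word, so this is the same change made on the second core. Because compound 3 sits at 12400 nM and the same change carried compound 1 to compound 2 as a 2.6-fold higher number from compound 1 to compound 2 (0.42 log units; beyond the scatter), compound 4 is expected to show a comparable step a 2.4-fold higher number from compound 3 to compound 4 (0.38 log units; beyond the scatter) in this assay. Whether the second core carries the change alike rests on nothing measured here. The estimate for compound 4 in this assay is 30000 nM, with a range from 12000 nM to 75000 nM.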

Compound 4, half-maximal inhibitory concentration: 8970 nM
Compound 4: middle estimate off by 3.3-fold (0.52 log units), on the high side; measured number below the stated range.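

In this assay, fluoro in place of trifluoromethyl on the second core gives a 1.4-fold lower number from compound 3 to compound 4 (0.14 log units; within the scatter), so compound 3 and compound 4 cannot be told apart on this read-out. Set beside the step on the first core, the same change did not carry over from one core to the other: the same change on two cores in this assay, a 2.6-fold higher number (0.42 log units; beyond the scatter) from compound 1 to compound 2 and a 1.4-fold lower number (0.14 log units; within the scatter) from compound 3 to compound 4, 3.6-fold (0.56 log units) apart, beyond the scatter of two such steps. This shows that the step seen on the first core cannot simply be transferred to the second core in this assay, but with a single pair on each core it does not show what in the cores sets the two steps apart, or whether any other change would behave in the same way.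

The compounds shown leave open how the two cores would respond to other groups on the same aromatic carbon, such as an amine, a nitrile or a carboxylic acid. They also leave open whether this change would follow either step on a third core.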